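Hydrazone aryl variation in a diaryl ether urea series

The compounds below may be only part of what the source reports. "The series", "measured", "known", "first", "only" and "open" are said of these compounds alone.

Measured so far:
compound 1 `CN(C)CCn1cnnc1-c1cc(Oc2ccc(NC(=O)N/N=C/c3cccc(Br)c3)cc2F)ccn1` — 380 nM
compound 2 `CN(C)CCn1cnnc1-c1cc(Oc2ccc(NC(=O)N/N=C/c3cccc(O)c3)cc2F)ccn1` — 330 nM
compound 3 `CN(C)CCn1cnnc1-c1cc(Oc2ccc(NC(=O)N/N=C/c3ccc(O)c(F)c3)cc2F)ccn1` — 3310 nM

Three compounds share the core and differ only in the aryl group on a carbon with a double bond to nitrogen. In a functional assay on HT-29 cells (Homo sapiens) for cytotoxicity, read by MTT assay, with a stated time of 72 h (on this read-out lower numbers stand for stronger inhibition and higher numbers for weaker inhibition), compound 3 gives the highest number of the three: an 8.7-fold higher number from compound 1 to compound 3 (0.94 log units; beyond the scatter) and a 10-fold higher number from compound 2 to compound 3 (1.00 log units; beyond the scatter). Between compound 1 and compound 2 the change is a 1.2-fold lower number from compound 1 to compound 2 (0.06 log units; within the scatter).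

Compound 4 `CN(C)CCn1cnnc1-c1cc(Oc2ccc(NC(=O)N/N=C/c3cc(Br)c(O)c(Br)c3)cc2F)ccn1` is the next member. The change from compound 3 is 3,5-dibromo-4-hydroxyphenyl in place of 3-fluoro-4-hydroxyphenyl on a carbon with a double bond to nitrogen. The hydroxy is kept, the fluorine is removed, and two bromines enter.

Among the compounds with values here, no measured step tracks this exact change. Within the data shown here, the steps that bear on it are those into compound 3, both beyond the scatter, which show that the 3-fluoro-4-hydroxyphenyl arrangement weakened the series relative to the 3-bromophenyl of compound 1 and the 3-hydroxyphenyl of compound 2. Compound 4 keeps the hydroxy that those steps associate with the higher number, so the expectation leans toward a number nearer compound 3 than compound 1, with some room for improvement because an 8.7-fold higher number from compound 1 to compound 3 (0.94 log units; beyond the scatter) shows the bromo-bearing aryl standing at the lower number. Compound 4 is therefore estimated at 1800 nM (range 450 nM to 7000 nM), a step of a 1.8-fold lower number from compound 3 to compound 4 (0.26 log units; within the scatter) expected with low confidence.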

Compound 4, half-maximal inhibitory concentration: 2670 nM
Beside the measured number, compound 4's estimate is 1.5-fold (0.17 log units) below it; the measured number falls inside the stated range.
By their numbers in this assay, from the lowest: compounds 2 and 1 (each within the scatter of the next); then compounds 4 and 3 (each within the scatter of the next).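

In this assay the 3,5-dibromo-4-hydroxyphenyl group of compound 4 stays level with the 3-fluoro-4-hydroxyphenyl group, with a 1.2-fold lower number from compound 3 to compound 4 (0.09 log units; within the scatter) at this carbon with a double bond to nitrogen, so replacing the fluorine with two bromines while keeping the hydroxy gives no readable change. The gap to the other two aryl groups remains, with an 8.1-fold higher number from compound 2 to compound 4 (0.91 log units; beyond the scatter) and a 7.0-fold higher number from compound 1 to compound 4 (0.85 log units; beyond the scatter) on the same read-out, so among these four compounds the two groups named as 4-hydroxyphenyl give the higher numbers, no compound shown goes against this, and bromine alone does not set the level, as compound 1 and compound 4 both carry it on opposite sides of that gap. Nothing available on these compounds speaks to what lies behind this grouping.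

The compounds shown leave open whether the hydroxy of the two weaker compounds is what sets their level, which a methoxy or an amine in its place, or a plain phenyl, would test. They also leave open whether a carboxylic acid on this aryl group would fall with compound 2 and compound 1 or with compound 3 and compound 4.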